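Replacing the Urea Linker in a Thiophene Sulfonamide Series

The source may report more compounds than this note shows. Statements on the series, on what has been measured and on what is new or still open speak of the compounds shown alone.

Measured compounds in a functional assay on RS4-11 cells (Homo sapiens) for inhibition, read by CCK-8 assay, with a stated time of 48 h; on this read-out higher numbers stand for weaker inhibition and lower numbers for stronger inhibition:
- compound 1 `O=C(NCCNS(=O)(=O)c1ccc(-c2ccccc2OCc2ccccc2)s1)Nc1cc(Cl)cc(Cl)c1`: > 20000 nM, which is a limit of the assay and not a number
- compound 2 `O=C(NCCNS(=O)(=O)c1ccc(-c2ccccc2Oc2ccc([N+](=O)[O-])c([N+](=O)[O-])c2)s1)Nc1cc(C(F)(F)F)cc(C(F)(F)F)c1`: 2400 nM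
- compound 3 `Cc1ccc(-c2ccsc2S(=O)(=O)NCCNC(=O)Nc2cccc([N+](=O)[O-])c2)c(Oc2ccc(O)c(O)c2)c1`: 9100 nM

Compound 3 stands at the highest of the two numbers that were actually read out in this assay. Its nearest neighbour is compound 2, whose number is lower by a gap beyond the usual scatter of repeated measurements. For compound 1, only a limit was recorded in this assay (the limit of > 20000 nM in this assay, at which 1 of the 3 values shown sits).

Compound 4 `Cc1ccc(-c2ccsc2S(=O)(=O)NCCNC(=S)Nc2cccc([N+](=O)[O-])c2)c(Oc2ccc(O)c(O)c2)c1` differs from compound 3 in a single place: a group of 12 heavy atoms (7 carbon, 2 nitrogen, 2 oxygen, 1 sulfur; one six-membered aromatic ring of carbon only) in place of a group of 12 heavy atoms (7 carbon, 2 nitrogen, 3 oxygen; one six-membered aromatic ring of carbon only), on an amine nitrogen, on an amine nitrogen whose other neighbour is a saturated chain carbon. For the measured compounds named here, no pair of measured compounds shows this particular change, so there is no measured step to lean on.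

Because compound 3 gives 9100 nM and the exchange keeps the ring, the hydrogen-bond donor and the acceptor count in place, the expected step of a 1.3-fold lower number from compound 3 to compound 4 (0.11 log units; within the scatter) is small and likely within the scatter. Compound 4 is therefore estimated at 7000 nM, within a range from 2500 nM to 20000 nM.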

Compound 4, half-maximal inhibitory concentration: 6100 nM
For compound 4 the middle estimate is 1.1-fold (0.06 log units) above the measured one; the range from low to high includes it.
By their numbers in this assay, from the lowest: compound 2; then compounds 4 and 3 (each within the scatter of the next). At a limit, above all of these: compound 1.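

Compound 3 and compound 4 are the first pair shown that differ in only one place, so this change can be read on its own. In this assay, the group on the amine nitrogen keeps its nitrophenyl ring and exchanges one oxygen for one sulfur, turning the urea into a thiourea; the result is a 1.5-fold lower number from compound 3 to compound 4 (0.17 log units; within the scatter), so at this position the two linkers cannot be told apart. Nothing measured here explains why this exchange leaves the read-out within the scatter.

A single pair cannot show whether the same holds when the urea gives way to a guanidine or a plain amide. It also leaves open whether a thiourea behaves the same way with a different aromatic ring on that linker, such as a pyridine.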